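Two more chain carbons on a non-cytotoxic sulfonamide

The source may hold more compounds than are shown below. What is called first, only, known or untested is meant among the compounds shown, and "the series" means these compounds.

Compound 1 `COc1ccc(S(=O)(=O)N(CC(N)=O)c2ccc(N(CC(N)=O)S(=O)(=O)c3ccc(NC(=O)CN4CCCCC4)cc3)c3ccccc23)cc1` in a functional assay on cells (Peritoneal macrophage, Mus musculus) for cytotoxicity, with a stated time of 24 h (a lower number here means that less compound is tolerated, a higher number that more compound is tolerated), gives > 100000 nM, which is a limit of the assay. Compound 2 `CCN1CCN(CC(=O)Nc2ccc(S(=O)(=O)N(CC(N)=O)c3ccc(N(CC(N)=O)S(=O)(=O)c4ccc(OC)cc4)c4ccccc34)cc2)CC1` in this assay gives > 100000 nM, again a limit. Compound 3 `COc1ccc(S(=O)(=O)N(CC(N)=O)c2ccc(N(CC(N)=O)S(=O)(=O)c3ccc(NC(=O)CCN4CCCCC4)cc3)c3ccccc23)cc1` in this assay gives > 100000 nM, again a limit.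

Compound 2 therefore stands at the limit of > 100000 nM in this assay, at which 3 of the 3 values shown sit, and no number for it is known. The measured steps between these three compounds, a step that the two limits leave unreadable from compound 1 to compound 2, a step that the two limits leave unreadable from compound 1 to compound 3 and a step that the two limits leave unreadable from compound 2 to compound 3, all compare one limit with another and show no size at all. The unmeasured compound 4 `CCN1CCN(CCCC(=O)Nc2ccc(S(=O)(=O)N(CC(N)=O)c3ccc(N(CC(N)=O)S(=O)(=O)c4ccc(OC)cc4)c4ccccc34)cc2)CC1` differs from compound 2 by 2-(4-ethylpiperazin-1-yl)ethyl in place of 4-ethylpiperazin-1-yl on a saturated chain carbon bound to a carbonyl carbon. Going by the values given here, the only comparable change among the measured compounds is the one between compound 1 and compound 3, which also lengthens the chain by one carbon and leaves both at the limit. Among the compounds with values here, compound 4 is therefore expected to show no step readable beyond the scatter, a step that the limit leaves unreadable from compound 2 to compound 4. The estimate for compound 4 in this assay is 120000 nM, with a range from 50000 nM to 300000 nM, most likely reported again as a limit.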

Compound 4, half-maximal cytotoxic concentration: > 100000 nM
Compound 4: only a limit was reported; the forecaster's own chance of this, stated with the estimate: 85%; the middle value lies beyond the limit too.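

In this assay compound 4 gives > 100000 nM, again a limit of the assay. Going by these compounds alone, compound 1, compound 2 and compound 3 sit at that same limit, so no step to compound 4 can be read. As far as these compounds go, whether these four compounds differ at all in cytotoxicity, and what the longer chain does, remains open.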